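Dichlorobenzimidazole series: swapping hydroxy for acetamido

A few compounds are considered here, and "the series" means these few. Any claim that something is new, unique, unknown or untested is made for them only; others in the source may bear on it.

The series rests on a shared core carrying a para-substituted phenyl group. Compound 1, `Oc1ccc(-c2nc3cc(Cl)c(Cl)cc3[nH]2)cc1`, gives 18000 nM in an ADME assay on Vero cells (Chlorocebus sabaeus) for cytotoxicity (on this read-out lower numbers stand for higher toxicity in this test and higher numbers for lower toxicity in this test), the lowest of the two numbers measured, with compound 2 the nearest and beyond the scatter. Compound 2, `CC(=O)Nc1ccc(-c2nc3cc(C(F)(F)F)ccc3[nH]2)cc1`, which carries the acetamido group on a differently substituted core, gives 50000 nM in this assay.

Compound 3, `CC(=O)Nc1ccc(-c2nc3cc(Cl)c(Cl)cc3[nH]2)cc1`, has not yet been measured. It differs from compound 1 as follows: acetamido in place of hydroxy on an aromatic carbon. Going by the values given here, no measured pair isolates this change, so the expected step rests on the observation that the only acetamido-bearing compound, compound 2, shows the higher number at 50000 nM.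

A modest step in this assay is expected, towards a higher number, possibly within the scatter, of the size a 1.7-fold higher number from compound 1 to compound 3 (0.22 log units; within the scatter). Compound 3 is estimated at 30000 nM, with a range from 12000 nM to 80000 nM.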

Compound 3, half-maximal cytotoxic concentration: > 100000 nM
Compound 3: a limit, no number; the forecaster's own chance of this, stated with the estimate: 25%; at least 3.3-fold (0.52 log units) between middle value and limit.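

The series now holds its first pair differing in one place: on the shared core, acetamido in place of hydroxy on an aromatic carbon, para to a large group, gives an at least 5.5-fold higher number from compound 1 to compound 3 (0.74 log units; beyond the scatter) in this assay. Compound 3 gives > 100000 nM, a limit of the assay and not a number: the limit of > 100000 nM in this assay, at which 1 of the 3 values shown sits.
At this position the change therefore moves the read-out towards lower toxicity in this test, beyond the scatter, which no earlier comparison could isolate.

As far as these compounds go, it remains open whether a plain amine or a carboxylic acid at this position would move the read-out the same way, or how a longer chain in place of the acetyl part of acetamido would read. From the compounds shown here alone, whether the same change holds on the core of compound 2 also remains open.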